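A few compounds are considered here, and "the series" means these few. Any claim that something is new, unique, unknown or untested is made for them only; others in the source may bear on it.

Measured compounds in an ADME assay on L02 cells (Homo sapiens) for cytotoxicity, read by MTT assay, with a stated time of 48 h; a higher number here means a weaker inhibitor, a lower number a stronger inhibitor:
Compound 1, `Cc1cccc(Cn2cc(COc3ccc4c(=O)ccoc4c3)nn2)c1`, gives > 300000 nM, a limit of the assay and not a number.
Compound 2, `Cc1ccc(Cn2cc(COc3ccc4c(=O)ccoc4c3)nn2)cc1`, gives > 300000 nM, again a limit.
Compound 3, `O=c1ccoc2cc(OCc3cn(Cc4ccccc4F)nn3)ccc12`, gives > 300000 nM, again a limit.

Compound 2 thus stands at the limit, and the two other values shown are limits too, so no ordering among the three can be read. The steps a step that the two limits leave unreadable from compound 1 to compound 2, a step that the two limits leave unreadable from compound 1 to compound 3 and a step that the two limits leave unreadable from compound 2 to compound 3 are all unreadable because of the limit of > 300000 nM in this assay, at which 3 of the 3 values shown sit. Compound 4, `O=c1ccoc2cc(OCc3cn(Cc4ccccc4Br)nn3)ccc12`, differs from compound 2 as 2-bromophenyl in place of 4-methylphenyl on a saturated chain carbon bound to an aromatic nitrogen. The three steps that bear on it give no size; they show only that 3-methylphenyl, 4-methylphenyl and 2-fluorophenyl at this place all left the value at the limit. In this assay compound 4 is therefore expected to sit at the limit as well, with no readable step a number no higher from compound 2 to compound 4 (the limit leaves the size open). The estimate for compound 4 is 300000 nM, ranging from 150000 nM to 600000 nM.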

Compound 4, half-maximal inhibitory concentration: > 300000 nM
Compound 4: only a limit was reported; the forecaster's own chance of this, stated with the estimate: 85%; the middle value sits exactly at the limit.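

No step among compound 1, compound 2, compound 3 and compound 4 can be read, as all four values are limits and not numbers: the limit of > 300000 nM in this assay, at which 4 of the 4 values shown sit.

The compounds shown leave open whether any group at this place gives a readable value in this assay.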